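This account rests on a few compounds, and the source may have more. Where it says the series, first, only, none or still open, it means among the compounds named here.

Measured in a functional assay on Lu1 cells (Homo sapiens) for cytotoxicity, read by sulforhodamine B assay; on this read-out lower numbers stand for an effect already at smaller amounts and higher numbers for an effect only at larger amounts of compound:
- compound 1 `C=C1CC[C@@H]2[C@](C)(COC(C)=O)[C@H](OC(C)=O)CC[C@@]2(C)[C@@H]1C/C=C1/C(=O)OC[C@H]1OC(C)=O`: 12.4 uM
- compound 2 `C=C1CC[C@@H]2[C@](C)(CO[Si](C(C)C)(C(C)C)C(C)C)[C@H](OC(C)=O)CC[C@@]2(C)[C@@H]1C/C=C1/C(=O)OC[C@H]1OC(C)=O`: 18.8 uM
- compound 3 `C=C1CC[C@@H]2[C@](C)(CO)[C@H](OC(C)=O)CC[C@@]2(C)[C@@H]1C/C=C1/C(=O)OC[C@H]1OC(C)=O`: 8.75 uM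

Compound 3 stands at the low end of these numbers. The measured step of a 1.4-fold lower number from compound 1 to compound 3 (0.15 log units; within the scatter) lies within the scatter, while a 2.1-fold lower number from compound 2 to compound 3 (0.33 log units; beyond the scatter) lies just beyond it and is modest.

The next compound is compound 4 `C=C1CC[C@@H]2[C@](C)(CO[Si](C)(C)C(C)(C)C)[C@H](OC(C)=O)CC[C@@]2(C)[C@@H]1C/C=C1/C(=O)OC[C@H]1OC(C)=O`, and its structural change is a group of 7 heavy atoms (6 carbon, 1 silicon; no ring) in place of a hydrogen atom, on an oxygen on a saturated carbon. Going by the values given here, the closest precedent is compound 2, which also has a silicon-bearing group on an oxygen on a saturated carbon, in its case a group of 10 heavy atoms (9 carbon, 1 silicon; no ring). Its step of a 2.1-fold lower number from compound 2 to compound 3 (0.33 log units; beyond the scatter) suggests that adding such a group to compound 3 may raise the number, although a single comparison is thin support. Compound 4 carries the smaller group, so a small rise in this assay is expected, no larger than that measured step. The expected step is a 1.6-fold higher number from compound 3 to compound 4 (0.20 log units; within the scatter). For compound 4 the estimated value is 14 uM, with an expected range of 7 uM to 28 uM.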

Compound 4, concentration for half-maximal effect: 2.92 uM
For compound 4 the middle estimate is 4.8-fold (0.68 log units) above the measured one; measured number outside the range, below it.
By their numbers in this assay, from the lowest: compound 4; then compounds 3, 1 and 2 (each within the scatter of the next, the first and the last beyond it).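

In this assay, silicon-bearing groups on this oxygen do not behave alike: a 6.4-fold lower number from compound 2 to compound 4 (0.81 log units; beyond the scatter), so the group of 7 heavy atoms (6 carbon, 1 silicon) and the group of 10 heavy atoms (9 carbon, 1 silicon) give clearly different numbers. Capping this oxygen can therefore lower the number as well as raise it, as a 3.0-fold lower number from compound 3 to compound 4 (0.48 log units; beyond the scatter) shows, and with a 4.2-fold lower number from compound 1 to compound 4 (0.63 log units; beyond the scatter) compound 4 has the lowest number of the four compounds. The data hold no measurement that would explain this difference between the two silicon-bearing groups.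

Going by these compounds alone, with only two such groups, it remains open how the number follows the make-up of the group on this oxygen. A trimethylsilyl ether or a benzyl ether at the same place would test whether compound 4 is an isolated case.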